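Ester in place of ketone on a furyl dihydropyrimidinone core

The source may report more compounds than this note shows. Statements on the series, on what has been measured and on what is new or still open speak of the compounds shown alone.

Compound 1 `CC1=C(C(=O)CC(C)C)C(c2ccco2)NC(=O)N1` stands highest of the three compounds measured in an assay on membranes from HeLa cells for displacement of a labelled ligand from adenosine receptor A3 (Homo sapiens), read by scintillation counting, with a stated time of 180 min, tested at 1 uM (a lower number here means less inhibition, a higher number more inhibition at the concentration tested (going by the name of the read-out)), where compound 1 gives 31%. Its nearest neighbour is compound 2 `CC1=C(C(=O)CC(C)C)C(c2cccs2)NC(=O)N1`, which in this assay gives 18%; the change of thiophen-2-yl in place of furan-2-yl on a saturated ring carbon brought a number 13 percentage points lower from compound 1 to compound 2 (beyond the scatter). Furthest is compound 3 `CC1=C(c2ncc(C)o2)C(c2ccco2)NC(=O)N1`, which in this assay gives 4% after 5-methyl-1,3-oxazol-2-yl replaced isobutylcarbonyl on a double-bonded ring carbon, a step of a number 27 percentage points lower from compound 1 to compound 3 (beyond the scatter).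

Compound 4 `CCC(CC)OC(=O)C1=C(C)NC(=O)NC1c1ccco1` has not been measured. It differs from compound 1 as follows: (pentan-3-yl)oxy in place of isobutyl on a carbonyl carbon. Going by the values given here, the step that bears most on this is the one from compound 1 to compound 3, since it also alters the group on the double-bonded ring carbon, though it removed the carbonyl altogether rather than changing what sits on it. Both measured steps ran downward, so a modest fall is expected, with the carbonyl retained keeping the loss smaller than a number 27 percentage points lower from compound 1 to compound 3 (beyond the scatter). For compound 4 the estimate is 22%, within 5% to 42%, meaning an expected step of a number 9 percentage points lower from compound 1 to compound 4 (within the scatter).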

Compound 4, a percentage reported as inhibition, at one concentration (the size of the read-out at that concentration, not a potency): 1%
The estimate for compound 4 lay 21 percentage points above the measured number; the measured number lies below the stated range.
By their numbers in this assay, from the lowest: compounds 4 and 3 (each within the scatter of the next); then compound 2; then compound 1.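

In this assay keeping the carbonyl on the double-bonded ring carbon did not hold the number up: (pentan-3-yl)oxy in place of isobutyl on that carbonyl carbon gave a number 30 percentage points lower from compound 1 to compound 4 (beyond the scatter), so what sits on the carbonyl counts here, not only whether a carbonyl is present. Compound 4, which keeps the carbonyl, and compound 3, which lacks it, lie within the scatter of each other, so these two changes cannot be told apart in this read-out. Nothing measured explains the loss.

The compounds shown leave open whether the loss belongs to the oxygen on the carbonyl carbon or to the chain behind it; a methoxy group, an ethoxy group or an amine at that place would separate the two. Also open, on these data alone, is whether thiophen-2-yl in place of furan-2-yl changes the number on an ester as it does on the ketone.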